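A few compounds are considered here, and "the series" means these few. Any claim that something is new, unique, unknown or untested is made for them only; others in the source may bear on it.

Compound 1 `CCCCCCCCCCCCCCCCCCCCCC(=O)O[C@H]1[C@H](O)[C@H](n2ccc(N)nc2=O)O[C@@H]1CO`: 1.1 ug/mL
Compound 2 `CCCC(=O)O[C@H]1[C@H](O)[C@H](n2ccc(N)nc2=O)O[C@@H]1CO`: 0.11 ug/mL
Compound 3 `CCCCCCCCCCCCCCCCCC(=O)O[C@H]1[C@H](O)[C@H](n2ccc(N)nc2=O)O[C@@H]1CO`: 0.13 ug/mL

Three esters of one shared core have been tested in a functional assay on HeLa cells (Homo sapiens) for cytotoxicity, read by cell counting, with a stated time of 48 h (a lower number here means that less compound is needed, a higher number that more compound is needed for the effect), with the numbers given above. Compound 3 stands second highest of the three; its number sits within the scatter of that of compound 2, while compound 1 lies well above it. Compound 4 `CCCCCCCCCCC(=O)O[C@H]1[C@H](O)[C@H](n2ccc(N)nc2=O)O[C@@H]1CO` differs from compound 3 by hydrogen in place of heptyl on a saturated chain carbon, ten or more bonds along the chain from a carbonyl carbon. Among the compounds with values here, the only measured step that bears on this change is an 8.5-fold lower number from compound 1 to compound 3 (0.93 log units; beyond the scatter), where a shorter chain brought a lower number. Yet compound 2, with the shortest chain of all, sits level with compound 3, so further shortening gives no further fall on these data. Compound 4 is therefore expected to stay near compound 3, with a step of a 1.1-fold lower number from compound 3 to compound 4 (0.03 log units; within the scatter) that is within the scatter. The estimate for compound 4 in this assay is 0.12 ug/mL, with a range from 0.05 ug/mL to 0.3 ug/mL.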

Compound 4, concentration for half-maximal effect: 0.04 ug/mL
Estimate against measurement, compound 4: 3.0-fold (0.48 log units) above; the whole stated range lies above it.
By their numbers in this assay, from the lowest: compound 4; then compounds 2 and 3 (each within the scatter of the next); then compound 1.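

In this assay the length of the chain still counts in the range where compound 2 and compound 3 looked level: hydrogen in place of heptyl gave a 3.3-fold lower number from compound 3 to compound 4 (0.51 log units; beyond the scatter) while heptyl in place of hydrogen on the shorter chain gave a 2.8-fold lower number from compound 2 to compound 4 (0.44 log units; beyond the scatter) and so compound 4 falls below both. With a 28-fold lower number from compound 1 to compound 4 (1.44 log units; beyond the scatter) as well, compound 4 has the lowest number of the four, and compound 2 goes against any steady fall as the chain shortens. Nothing available here explains this turn. The compounds shown leave open how the numbers run for chain lengths between those of compound 2 and compound 4, and between those of compound 4 and compound 3. They also leave open whether an amine or a carboxylic acid on the chain of compound 4 would keep its low number.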